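One more methyl on compound 2

The source may hold more compounds than are shown below. What is called first, only, known or untested is meant among the compounds shown, and "the series" means these compounds.

Three compounds share one core and differ only in the substituted phenyl group they carry: compound 1 `COC1=C(C)C(=O)/C(=C(O)/C=C/c2ccc(F)cc2)C(=O)C1(C)C`, compound 2 `COC1=C(C)C(=O)/C(=C(O)/C=C/c2c(C)cccc2C)C(=O)C1(C)C` and compound 3 `COC1=C(C)C(=O)/C(=C(O)/C=C/c2cc(C)cc(C)c2)C(=O)C1(C)C`. In a functional assay on HUVEC cells (Homo sapiens) (a lower number here means that less compound is needed, a higher number that more compound is needed for the effect), compound 1 gives < 4 ug/mL, which is a limit of the assay and not a number. Compound 2 gives < 4 ug/mL, again only a limit. Compound 3 gives < 4 ug/mL, also a limit. Compound 2 therefore has no exact place on the scale, and neither do its two neighbours.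

Compound 4 `COC1=C(C)C(=O)/C(=C(O)/C=C/c2c(C)cc(C)cc2C)C(=O)C1(C)C` is compound 2 with methyl in place of hydrogen on an aromatic carbon. The nearest measured comparisons are a step that the two limits leave unreadable from compound 1 to compound 2 and a step that the two limits leave unreadable from compound 2 to compound 3, along with a step that the two limits leave unreadable from compound 1 to compound 3. None of them has a readable size, so no step beyond the scatter, and no direction, is expected in this assay. The estimated change is a step that the limit leaves unreadable from compound 2 to compound 4. For compound 4 the expected value is 2 ug/mL, with an estimated range from 0.5 ug/mL to 5 ug/mL.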

Compound 4, concentration for half-maximal effect: < 4 ug/mL
Compound 4 gave a limit, no number; the forecaster's own chance of this, stated with the estimate: 75%; the middle value does not contradict the limit.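

Compound 2 and compound 4 both give only a limit, so the step between them cannot be read, and the added methyl gets no size. Compound 1, compound 2, compound 3 and compound 4 leave open whether their phenyl groups separate them at all in this assay, since all rest on one limit: the limit of < 4 ug/mL in this assay, at which 4 of the 4 values shown sit.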